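The compounds below may be only part of what the source reports. "The series", "measured", "known", "first", "only" and "open" are said of these compounds alone.

Compound 1 `CC(O)(COc1ccc(S(F)(F)(F)(F)F)cc1)C(=O)Nc1ccc(S(F)(F)(F)(F)F)cc1` and compound 2 `CC(O)(COc1cccc(S(F)(F)(F)(F)F)c1)C(=O)Nc1cccc(S(F)(F)(F)(F)F)c1` are built from the same atoms joined differently; how the two cores differ is not broken down here. In a functional assay on CWR22R cells (Homo sapiens) for antiproliferative activity, read by propidium iodide staining, with a stated time of 96 h (on this read-out lower numbers stand for stronger inhibition and higher numbers for weaker inhibition), compound 1 gives 13000 nM, the lowest of the three measured numbers, and compound 2 gives 27300 nM. Compound 3 `CC(O)(COc1cccc(C(F)(F)F)c1)C(=O)Nc1cccc(S(F)(F)(F)(F)F)c1` gives 28900 nM in this assay. Going from compound 2 to compound 3 makes one change, (a group of 4 heavy atoms (1 carbon, 3 fluorine; no ring) in place of a group of 6 heavy atoms (5 fluorine, 1 sulfur; no ring), on an aromatic carbon), and that change produced a 1.1-fold higher number from compound 2 to compound 3 (0.02 log units; within the scatter), so the two compounds cannot be told apart on this read-out.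

Compound 4 `CC(O)(COc1ccc(S(F)(F)(F)(F)F)cc1)C(=O)Nc1ccc(C(F)(F)F)cc1` has not yet been tested. It stands to compound 1 as compound 3 stands to compound 2: the change is a group of 4 heavy atoms (1 carbon, 3 fluorine; no ring) in place of a group of 6 heavy atoms (5 fluorine, 1 sulfur; no ring), on an aromatic carbon. This is the same kind of change, not the same one, since in compound 3 the new group sits meta to a large group, while in compound 4 it sits para to a large group. Because the measured instance gave a 1.1-fold higher number from compound 2 to compound 3 (0.02 log units; within the scatter), compound 4 is expected to stay close to compound 1, with an estimated step of a 1.1-fold higher number from compound 1 to compound 4 (0.05 log units; within the scatter). Compound 4 is therefore estimated at 14500 nM, likely between 6500 nM and 32000 nM.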

Compound 4, half-maximal inhibitory concentration: 12900 nM
Compound 4: the middle estimate sits 1.1-fold (0.05 log units) above what was measured; the measured number falls inside the stated range.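

In this assay, putting trifluoromethyl in place of the larger group of sulfur and fluorine on the core of compound 1 gave a 1.0-fold lower number from compound 1 to compound 4 (0.00 log units; within the scatter), so compound 4 and compound 1 cannot be told apart on this read-out. The same swap has now been read on two cores, and the two results do not differ: the same change on two cores in this assay, a 1.1-fold higher number (0.02 log units; within the scatter) from compound 2 to compound 3 and a 1.0-fold lower number (0.00 log units; within the scatter) from compound 1 to compound 4, 1.1-fold (0.03 log units) apart, within the scatter of two such steps. This shows that, for these two pairs, the swap carried from one core to the other without a visible shift in the number, but it does not show that the same would hold on other cores or in other assays, and it gives no reason for the result.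

The compounds shown leave open how a nitrile, an amine or a carboxylic acid would read in place of these groups. They also leave open whether the number would hold if trifluoromethyl replaced the sulfur and fluorine group on both aromatic rings at once.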